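Fluorine removal on the aryl ring: compound 1 to compound 4

This account rests on a few compounds, and the source may have more. Where it says the series, first, only, none or still open, it means among the compounds named here.

Measured so far in a functional assay on HL-60 cells (Homo sapiens) for inhibition, read by MTT assay, with a stated time of 48 h, tested at 10 uM; a lower number here means less inhibition of growth, a higher number more inhibition of growth at the concentration tested:
compound 1 `O=C(N/N=C/c1ccc(-c2ccc(F)cc2F)o1)c1ccccc1O` gives -9.5%
compound 2 `COc1ccccc1C(=O)N/N=C/c1ccc(-c2ccc(F)cc2F)o1` gives 7.77%
compound 3 `O=C(N/N=C/c1ccc(O)cc1)c1ccc(-c2ccc(F)cc2)o1` gives 1.07%

Compound 1 stands lowest of the three numbers; compound 3 is nearest, compound 2 furthest. For the measured compounds named here, the single one-point step known is a number 17.3 percentage points higher from compound 1 to compound 2 (beyond the scatter), a change on the phenol oxygen, not on the aryl ring.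

Compound 4 `O=C(N/N=C/c1ccc(-c2ccc(F)cc2)o1)c1ccccc1O` differs from compound 1 by hydrogen in place of fluoro on an aromatic carbon, placed on an aromatic carbon of a six-membered aromatic ring of carbon only. Going by the values given here, no measured step bears on this change; compound 3 carries a 4-fluorophenyl but differs from compound 1 in more than one place, so its value stands alone. Compound 4 is therefore expected to stay close to compound 1, with a number 6.5 percentage points higher from compound 1 to compound 4 (within the scatter) not beyond the scatter. The estimate for compound 4 in this assay is -3%, range -16% to 12%.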

Compound 4, percent growth inhibition at one concentration: -2.08%
Estimate against measurement, compound 4: 0.9 percentage points below; low and high end bracket the measured number.
By their numbers in this assay, from the lowest: compounds 1, 4, 3 and 2 (each within the scatter of the next, the first and the last beyond it).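

For the compounds shown here, the swap of 2,4-difluorophenyl for 4-fluorophenyl reads a number 7.4 percentage points higher from compound 1 to compound 4 (within the scatter) and is the first one-place step on the aryl ring, the earlier step having been on the phenol oxygen. At this position, ortho to a large group, hydrogen and fluoro cannot be told apart on the core of compound 1. No evidence on the cause of this result is at hand. Open, going by these compounds, is how an amine or a carboxylic acid would read on this aromatic carbon. Also open, on these data alone, is whether a methyl on the phenol oxygen gives a comparable step with 4-fluorophenyl.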